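The source may hold more compounds than are shown below. What is called first, only, known or untested is meant among the compounds shown, and "the series" means these compounds.

compound 1 `O=C(Cc1csc2nc(-c3ccc(Br)cc3)cn12)N/N=C/c1ccccc1` gives 32400 nM
compound 2 `O=C(Cc1csc2nc(-c3ccc(Br)cc3)cn12)N/N=C/c1ccccc1O` gives 11500 nM

In a functional assay on IGROV-1 cells (Homo sapiens) for inhibition, read by sulforhodamine B assay, with a stated time of 48 h (a higher number here means a weaker inhibitor of growth, a lower number a stronger inhibitor of growth), compound 2 has the lower of the two numbers, so it is the stronger inhibitor of this pair. Compound 3 `O=C(Cc1csc2nc(-c3ccc(Br)cc3)cn12)N/N=C/c1ccc(O)cc1` has the same atoms, joined differently: 4-hydroxyphenyl in place of 2-hydroxyphenyl on a carbon with a double bond to nitrogen. Among the compounds with values here, one measured step bears on this change. Hydroxy in place of hydrogen on an aromatic carbon gave a 2.8-fold lower number from compound 1 to compound 2 (0.45 log units; beyond the scatter), a modest step that covers only the 2-hydroxyphenyl group. Within the data shown here, no measured compound shows the 4-hydroxyphenyl group. Compound 3 is therefore expected to keep some or all of that gain, and to lie near compound 2 or somewhat toward compound 1. The expected step is small and upward: a 1.4-fold higher number from compound 2 to compound 3 (0.14 log units; within the scatter). For compound 3 the estimated value is 16000 nM, with an expected range of 7000 nM to 35000 nM.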

Compound 3, concentration for total growth inhibition: 39800 nM
Compound 3: middle estimate off by 2.5-fold (0.40 log units), on the low side; the measured number lies above the stated range.
By their numbers in this assay, from the lowest: compound 2; then compounds 1 and 3 (each within the scatter of the next).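

Where the hydroxy group sits on this ring matters: 4-hydroxyphenyl in place of 2-hydroxyphenyl on a carbon with a double bond to nitrogen gives a 3.5-fold higher number from compound 2 to compound 3 (0.54 log units; beyond the scatter) in this assay. Adding a hydroxy group therefore does not help in general here, since the change to 4-hydroxyphenyl gives a 1.2-fold higher number from compound 1 to compound 3 (0.09 log units; within the scatter), leaving compound 1 and compound 3 indistinguishable, and the gain seen so far belongs to the 2-hydroxyphenyl group alone. No measurement here offers a reason for the difference between the two placements.

On these data alone, it remains open whether the gain needs the hydroxy group itself, or whether a methoxy group or an amine in its place within the 2-hydroxyphenyl group would do the same. As far as these compounds go, it is also open whether the preference would survive with chlorine in place of the bromine on the shared core.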